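The source may report more compounds than this note shows. Statements on the series, on what has been measured and on what is new or still open speak of the compounds shown alone.

The measured compounds are:

Compound 1 `CC1(C)CC(=O)C2=C(C1)N(c1ccccc1)C(c1ccc(Br)cc1)N(c1ccccc1)C2` — in an ADME assay on BHK-21 cells (Mesocricetus auratus) for cytotoxicity, read by MTT assay, with a stated time of 48 h (on this read-out higher numbers stand for lower toxicity in this test and lower numbers for higher toxicity in this test), compound 1 gives > 20000 nM, which is a limit of the assay and not a number.
Compound 2 `CC1(C)CC(=O)C2=C(C1)N(c1ccccc1)C(c1cccc(C(F)(F)F)c1)N(c1ccccc1)C2` — in this assay compound 2 gives 17900 nM.
Compound 3 `CC1(C)CC(=O)C2=C(C1)N(c1ccccc1)C(c1ccc(Br)cc1)N(c1ccc(Cl)cc1)C2` — in this assay compound 3 gives 12700 nM.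

Compound 1 therefore stands only at a limit; it is one of the values sitting at the limit of > 20000 nM in this assay, at which 1 of the 3 values shown sits, so its true number is not pinned down. Compound 4 `CC1(C)CC(=O)C2=C(C1)N(c1ccccc1)C(c1ccc(Br)cc1)N(c1ccc(Oc3ccccc3)cc1)C2` differs from compound 1 by phenoxy in place of hydrogen on an aromatic carbon. Two measured steps start from compound 1. The closer one is an at least 1.5-fold lower number from compound 1 to compound 3 (0.19 log units; that floor lies within the scatter), a substituent entering the same kind of aromatic position; the other is an at least 1.1-fold lower number from compound 1 to compound 2 (0.04 log units; that floor lies within the scatter), at the saturated ring carbon. Both run toward lower numbers, yet each only sets a floor within the scatter, because compound 1 sits at the limit of > 20000 nM in this assay, at which 1 of the 3 values shown sits. A phenoxy group is larger than chloro, so a step at least as large, toward lower numbers, is expected: an at least 2.0-fold lower number from compound 1 to compound 4 (0.30 log units; that floor lies within the scatter). Compound 4 is estimated at 10000 nM, with a range from 4000 nM to 25000 nM.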

Compound 4, half-maximal cytotoxic concentration: 10900 nM
Compound 4: the middle estimate sits 1.1-fold (0.04 log units) below what was measured; low and high end bracket the measured number.
By their numbers in this assay, from the lowest: compounds 4, 3 and 2 (each within the scatter of the next). At a limit, above all of these: compound 1.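

For the compounds shown here, putting phenoxy, with its 7 heavy atoms and its own six-membered aromatic ring, in place of chloro on this aromatic carbon gives a 1.2-fold lower number from compound 3 to compound 4 (0.07 log units; within the scatter), so in this assay the two groups cannot be told apart, which the earlier compounds could not show. Measured against hydrogen, phenoxy gives an at least 1.8-fold lower number from compound 1 to compound 4 (0.26 log units; that floor lies within the scatter), a floor of the same kind as the one seen with chloro. The true size of the change from hydrogen stays unknown, as the value of compound 1 is a limit and not a number: the limit of > 20000 nM in this assay, at which 1 of the 4 values shown sits.

As far as these compounds go, it remains open whether any substituent at this position truly lowers the number relative to hydrogen. From the compounds shown here alone, it is equally open whether an amine or a carboxylic acid on this aromatic carbon would move the number beyond the scatter.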